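This account rests on a few compounds, and the source may have more. Where it says the series, first, only, none or still open, it means among the compounds named here.

Measured compounds:
Compound 1 `COc1cc(-c2nnc(SCC(=O)Nc3ccc(/C(C)=N/O)cc3)n2-c2ccccc2)cc(OC)c1OC` gives 66%
Compound 2 `CCn1c(SCC(=O)Nc2ccc(C(C)=O)cc2)nnc1-c1cc(OC)c(OC)c(OC)c1` gives 54%
Compound 3 `COc1ccc(-c2nnc(SCC(=O)Nc3ccc(C(C)=O)cc3)n2-c2ccccc2)cc1` gives 58%

All three were tested in a functional assay on the whole organism (strain albino) for inhibition, with Rattus norvegicus as the target, read by paw edema, with stated times of 30 min and 3 h, at a dose of 0.28 mmol/kg by the oral route; on this read-out higher numbers stand for more inhibition at the one dose given (going by the name of the read-out) and lower numbers for less inhibition. Compound 3 sits between the other two on this read-out, and both neighbours lie within the usual scatter of it: the number for compound 2 is close below, that for compound 1 close above, so no ranking among the three can be claimed. Compound 1 shares with compound 3 the phenyl group on the shared core and carries the 3,4,5-trimethoxyphenyl that compound 4 receives, while compound 2 carries that same trimethoxyphenyl with an ethyl group on the core instead of phenyl.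

Compound 4 `COc1cc(-c2nnc(SCC(=O)Nc3ccc(C(C)=O)cc3)n2-c2ccccc2)cc(OC)c1OC` has not yet been tested in this assay. It differs from compound 3 in one place: 3,4,5-trimethoxyphenyl in place of 4-methoxyphenyl on an aromatic carbon. Within the data shown here, no step between measured compounds isolates this change. Since compound 1, which also carries the 3,4,5-trimethoxyphenyl, gives 66% and compound 2 gives 54%, the expected step from compound 3 is small and not beyond the scatter in either direction. Compound 4 is estimated at 62%, in the range 50% to 74%, which means an expected step of a number 4 percentage points higher from compound 3 to compound 4 (within the scatter).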

Compound 4, a percentage reported as inhibition, in the whole organism at one dose (the size of the read-out at that dose, not a potency): 55%
Compound 4: middle estimate off by 7 percentage points, on the high side; the measured number falls inside the stated range.
By their numbers in this assay, from the lowest: compounds 2, 4, 3 and 1 (each within the scatter of the next, the first and the last beyond it).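

In this assay, the exchange of 4-methoxyphenyl for 3,4,5-trimethoxyphenyl on the aromatic carbon of the shared core can now be read directly as a number 3 percentage points lower from compound 3 to compound 4 (within the scatter), so the larger group at this position brings no change that can be told from the scatter, and the same holds with the 3,4,5-trimethoxyphenyl kept in place and phenyl in place of ethyl on the aromatic nitrogen, which reads as a number 1 percentage points higher from compound 2 to compound 4 (within the scatter). Among these compounds, the only step that clears the scatter lies at the other end of the molecule, where a group of 3 heavy atoms in place of a group of 4 heavy atoms on an aromatic carbon gives a number 11 percentage points lower from compound 1 to compound 4 (beyond the scatter), a modest difference resting on a single pair of compounds. Nothing in the data shown accounts for any of these steps.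

From the compounds shown here alone, it remains open whether that modest step would recur with 4-methoxyphenyl or with ethyl on the shared core. The compounds shown also leave open how a carboxylic acid or an amine on that same aromatic carbon, or a longer chain on the aromatic nitrogen, would read.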